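A few compounds are considered here, and "the series" means these few. Any claim that something is new, unique, unknown or untested is made for them only; others in the source may bear on it.

Compound 1 `COc1nc(N)nc2c1c(-c1cc3ccccc3o1)cn2[C@@H]1O[C@H](CO)[C@@H](O)[C@H]1O` gives 14600 nM in a functional assay on K562 cells (Homo sapiens), read by MTT assay, with a stated time of 72 h; a lower number here means a stronger inhibitor, a higher number a weaker inhibitor.
Compound 2 `Nc1nc2c(c(-c3ccccc3)cn2[C@@H]2O[C@H](CO)[C@@H](O)[C@H]2O)c(=O)[nH]1` is reported in this assay only as a limit of the assay, > 20000 nM, not as a number.
Compound 3 `Cc1ncnc2c1c(-c1cccs1)cn2[C@@H]1O[C@H](CO)[C@@H](O)[C@H]1O` is likewise reported in this assay only as a limit of the assay, > 20000 nM, not as a number.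

Among the three measured compounds, compound 1 is the only one with an actual number; the other two reach the ceiling of what this assay can report. Compound 3 thus stands at the limit of > 20000 nM in this assay, at which 2 of the 3 values shown sit. No pair of these compounds differs in just one place, so no single measured step shows how a small change moves the result.

Compound 4 `CNc1ncnc2c1c(-c1cccs1)cn2[C@@H]1O[C@H](CO)[C@@H](O)[C@H]1O` differs from compound 3 by methylamino in place of methyl on an aromatic carbon. Among the compounds with values here, nothing among the measured compounds tells how this particular exchange acts, so any expectation is an extrapolation rather than a reading of a step. Since compound 3 sits at a limit, the step from it can only be estimated as moving toward stronger inhibition or staying flat, and the estimate made here is that the step of an at least 330-fold lower number from compound 3 to compound 4 (2.52 log units; beyond the scatter) is a clear gain, well beyond the usual scatter. Compound 4 is accordingly expected to give about 60 nM in this assay, with a plausible range from 5 nM to 3000 nM.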

Compound 4, half-maximal inhibitory concentration: > 20000 nM
Compound 4: only a limit was reported; the forecaster's own chance of this, stated with the estimate: 15%; middle value at least 330-fold (2.52 log units) away from the limit.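

Compound 4, like compound 3, is reported in this assay only as a limit, so the exchange of methyl for methylamino between these two compounds cannot be read as a step: the limit of > 20000 nM in this assay, at which 3 of the 4 values shown sit. The compounds shown leave open whether this exchange changes inhibition at all, and how compound 3 and compound 4 would compare if each had an actual number.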